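Cytotoxicity notes on four related compounds

The compounds below may be only part of what the source reports. "The series", "measured", "known", "first", "only" and "open" are said of these compounds alone.

Compound 1 `CCOC(=O)c1c(-c2cccc(F)c2)[nH]c2cc(OC)ccc2c1=O` is the reference. In an ADME assay on BJ cells (Homo sapiens) for cytotoxicity, read by luminescence, with a stated time of 72 h (on this read-out lower numbers stand for an effect already at smaller amounts and higher numbers for an effect only at larger amounts of compound), compound 1 reaches only the assay limit, > 21500 nM. Compound 2 `CCOC(=O)c1c(-c2cccc(Cl)c2)[nH]c2cc(OC)ccc2c1=O` differs by chloro in place of fluoro on an aromatic carbon. In this assay compound 2 likewise stops at the limit, > 21500 nM. The step that the two limits leave unreadable from compound 1 to compound 2 is thus not readable in size. Compound 3 `CCOC(=O)c1c(-c2cccc(F)c2)[nH]c2cc(OC)c(F)cc2c1=O` differs from compound 1 by fluoro in place of hydrogen on an aromatic carbon. In this assay compound 3 also sits at the limit, > 21500 nM. All three values rest at the limit of > 21500 nM in this assay, at which 3 of the 3 values shown sit. Compound 4 `CCOC(=O)c1c(-c2cccc(Cl)c2)[nH]c2cc(OC)c(F)cc2c1=O`, not yet measured, differs from compound 3 by chloro in place of fluoro on an aromatic carbon, the same change as from compound 1 to compound 2. The step that the limit leaves unreadable from compound 3 to compound 4 is expected to be small, since the matching step that the two limits leave unreadable from compound 1 to compound 2 showed no readable movement. Compound 4 is expected at 30000 nM in this assay, within an estimated range of 15000 nM to 90000 nM, most likely reported again as a limit only.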

Compound 4, half-maximal effective concentration: > 21500 nM
Compound 4 was reported as a limit; the forecaster's own chance of this, stated with the estimate: 85%; the middle value is on the limit's open side.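

Compound 4 adds no readable step: the steps to it from compound 3 and from compound 2 cannot be read, and all four compounds rest at one assay limit: the limit of > 21500 nM in this assay, at which 4 of the 4 values shown sit.

The compounds shown leave open whether either change, chloro for fluoro or fluoro for hydrogen, shifts cytotoxicity in this assay.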